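From 2-methylphenyl to phenyl on the shared core

The source may report more compounds than this note shows. Statements on the series, on what has been measured and on what is new or still open speak of the compounds shown alone.

Measured so far in a functional assay on HeLa cells (Homo sapiens) for antiproliferative activity, read by sulforhodamine B assay, with a stated time of 72 h (on this read-out lower numbers stand for stronger inhibition and higher numbers for weaker inhibition), are three compounds:
compound 1 (`S=C(NCc1ccccc1)N/N=C/c1ccc2ccccc2n1`) at 62800 nM
compound 2 (`S=C(N/N=C/c1ccc2ccccc2n1)Nc1cccc(Br)c1`) at 70000 nM
compound 3 (`Cc1ccccc1NC(=S)N/N=C/c1ccc2ccccc2n1`) at > 100000 nM as a limit

Compound 3 has no number, only a limit of the assay (> 100000 nM). Compound 4 (`S=C(N/N=C/c1ccc2ccccc2n1)Nc1ccccc1`) carries hydrogen in place of methyl on an aromatic carbon, ortho to a large group (hydrogen in place of methyl on an aromatic carbon). For the measured compounds named here, no measured step makes this change directly. The closest are two steps to compound 3 (an at least 1.5-fold higher number from compound 1 to compound 3 (0.20 log units; that floor lies within the scatter)) and (an at least 1.4-fold higher number from compound 2 to compound 3 (0.15 log units; that floor lies within the scatter)). Compound 1 and compound 2 also lie together (a 1.1-fold higher number from compound 1 to compound 2 (0.05 log units; within the scatter)), so a modest move toward lower numbers in this assay is expected. The expected step is (an at least 1.3-fold lower number from compound 3 to compound 4 (0.12 log units; that floor lies within the scatter)). Compound 4 is estimated at 75000 nM with a range from 35000 nM to 110000 nM.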

Compound 4, half-maximal inhibitory concentration: 27400 nM
For compound 4 the middle estimate is 2.7-fold (0.44 log units) above the measured one; measured number below the stated range.
By their numbers in this assay, from the lowest: compound 4; then compounds 1 and 2 (each within the scatter of the next). At a limit, above all of these: compound 3.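

In this assay, for the compounds shown here, replacing the methyl of the 2-methylphenyl group with hydrogen gives an at least 3.6-fold lower number from compound 3 to compound 4 (0.56 log units; beyond the scatter), the first step in this set that clears the scatter. The plain phenyl also separates from the other two compounds, with a 2.6-fold lower number from compound 2 to compound 4 (0.41 log units; beyond the scatter) and a 2.3-fold lower number from compound 1 to compound 4 (0.36 log units; beyond the scatter), so any substituent or spacer shown here goes with a higher number. Compound 3 stands only at a limit, so the full size of its step stays unknown: the limit of > 100000 nM in this assay, at which 1 of the 4 values shown sits.

On these data alone, whether a fluoro or a methoxy on that same aromatic carbon would track with hydrogen or with methyl remains open.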